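A few compounds are considered here, and "the series" means these few. Any claim that something is new, unique, unknown or untested is made for them only; others in the source may bear on it.

Measured so far:
- compound 1, `C=CCc1c(SC)nc2nc(C(=O)c3ccccc3)cn2c1C`: 5 mg/kg
- compound 2, `CCCCc1c(OC)nc2nc(C(=O)c3ccccc3)cn2c1C`: 2 mg/kg

Both were tested in a functional assay on the whole organism with Rattus norvegicus as the target; a lower number here means that less compound is needed, a higher number that more compound is needed for the effect. Among the compounds with values here, compound 1 needs 5 mg/kg, while compound 2 needs 2 mg/kg, the lowest of the two numbers known here; the gap between compound 1 and compound 2 lies beyond the usual scatter of repeated measurements.

Compound 3, `C=CCc1c(OC)nc2nc(C(=O)c3ccccc3)cn2c1C`, has not been measured in this assay. Compared with compound 2 it carries one change: vinyl in place of propyl on a saturated chain carbon bound to an aromatic carbon. Within the data shown here, no measured pair shows this change on its own, so there is no direct precedent for its effect. A small step is expected, if any, and the direction is uncertain; the step from compound 2 to compound 3 in this assay is expected to be about a 1.5-fold higher number from compound 2 to compound 3 (0.18 log units; within the scatter).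

For compound 3 the estimated minimum effective dose in this assay is 3 mg/kg, with a likely range from 1.5 mg/kg to 6 mg/kg.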

Compound 3, minimum effective dose: 5 mg/kg
Compound 3: the middle estimate sits 1.7-fold (0.22 log units) below what was measured; measured number inside the range.
By their numbers in this assay, from the lowest: compound 2; then compounds 1 and 3 (each within the scatter of the next).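

In this assay, the chain on the saturated carbon bound to an aromatic carbon proves to matter: vinyl in place of propyl, which also reads as butyl to allyl, gives a 2.5-fold higher number from compound 2 to compound 3 (0.40 log units; beyond the scatter). Methoxy in place of methylsulfanyl on an aromatic carbon, with the allyl chain held constant, gives no change at the digits printed from compound 1 to compound 3 (within the scatter), so of these two changes only the chain change shows a step beyond the scatter. Nothing available here offers an explanation for this difference.

The compounds shown leave open whether methoxy and methylsulfanyl would also match if the chain were butyl instead of allyl. They also leave open how a longer chain such as hexyl, or a chain ending in an amine, would behave at this position.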